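Alanine-to-glycine exchange across two chain-linked pairs

The compounds below may be only part of what the source reports. "The series", "measured", "known", "first", "only" and "open" are said of these compounds alone.

Of the compounds shown here, three have been measured in a functional assay on MCF7 cells (Homo sapiens) for cytotoxicity, read by MTT assay, with a stated time of 48 h; on this read-out higher numbers stand for weaker inhibition and lower numbers for stronger inhibition. Compound 1 `CC(C)=CCC/C(C)=C/CC/C(C)=C/CSc1ccccc1C(=O)N[C@@H](C)C(=O)OC(C)CCOc1no[n+]([O-])c1S(=O)(=O)c1ccccc1` gives 11100 nM in this assay. Compound 2 `CC(C)=CCC/C(C)=C/CC/C(C)=C/CSc1ccccc1C(=O)N[C@@H](C)C(=O)OCCCCOc1no[n+]([O-])c1S(=O)(=O)c1ccccc1` gives 8680 nM, and compound 3 `CC(C)=CCC/C(C)=C/CC/C(C)=C/CSc1ccccc1C(=O)NCC(=O)OCCCCOc1no[n+]([O-])c1S(=O)(=O)c1ccccc1` gives 25100 nM. The numbers for compound 1 and compound 2 lie within the scatter of each other; compound 1 against compound 3 lies beyond it.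

Compound 2 and compound 3 differ in one place: hydrogen in place of methyl on a saturated chain carbon bound to an amide-type nitrogen and a carbonyl carbon. This change brought a 2.9-fold higher number from compound 2 to compound 3 (0.46 log units; beyond the scatter). Compound 1 and compound 2 have the same atoms joined differently; the difference between the two cores is not broken down here.

Compound 4 `CC(C)=CCC/C(C)=C/CC/C(C)=C/CSc1ccccc1C(=O)NCC(=O)OC(C)CCOc1no[n+]([O-])c1S(=O)(=O)c1ccccc1` has not been measured. Against compound 1 it carries the same change, (hydrogen in place of methyl on a saturated chain carbon bound to an amide-type nitrogen and a carbonyl carbon), at a place described in the same words as for the pair from compound 2 to compound 3. Within the data shown here, with only one measured instance of this change, the expectation can rest on nothing else.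

Among the measured compounds shown here, for compound 4 the step is expected to be about a 2.9-fold higher number from compound 1 to compound 4 (0.46 log units; beyond the scatter) in this assay, because a 2.9-fold higher number from compound 2 to compound 3 (0.46 log units; beyond the scatter) is the one prior reading of this change. Compound 4 is accordingly estimated at 32000 nM, with a plausible range from 15000 nM to 70000 nM, the width reflecting that a single precedent and the usual scatter both enter.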

Compound 4, half-maximal inhibitory concentration: 9110 nM
For compound 4 the middle estimate is 3.5-fold (0.55 log units) above the measured one, and the stated range ends above it.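

In this assay, hydrogen in place of methyl on a saturated chain carbon bound to an amide-type nitrogen and a carbonyl carbon gives a 1.2-fold lower number from compound 1 to compound 4 (0.09 log units; within the scatter), so on the core of compound 1 this exchange leaves the number within the scatter, unlike the step on the core of compound 2. Among these compounds, the two readings of the one change do not agree: the same change on two cores in this assay, a 2.9-fold higher number (0.46 log units; beyond the scatter) from compound 2 to compound 3 and a 1.2-fold lower number (0.09 log units; within the scatter) from compound 1 to compound 4, 3.5-fold (0.55 log units) apart, beyond the scatter of two such steps This shows that the change cannot be carried as a fixed step between these two cores, even though they have the same atoms joined differently; it does not show what sets the two cores apart, nor which of the two readings is the more typical, since each core supplies a single pair.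

Still open, going by these compounds, is whether the gap between the two cores persists when an ethyl group or a longer chain stands in place of methyl on that same chain carbon. Also open, on these data alone, is whether it holds for a carboxylic acid in place of the ester, and for any cell line other than the one read here.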